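Replacing 2-methoxyphenyl with 4-nitrophenyl on the shared core

This account rests on a few compounds, and the source may have more. Where it says the series, first, only, none or still open, it means among the compounds named here.

In a functional assay on MCF7 cells (Homo sapiens) for antiproliferative activity, read by MTT assay, with a stated time of 72 h (a higher number here means a weaker inhibitor, a lower number a stronger inhibitor), compound 1 (`COc1ccccc1-c1ccc2ncn(-c3cc(OC)c(OC)c(OC)c3)c2c1`) gives 1750 nM and compound 2 (`COc1cc(-n2cnc3ccc(-c4ccc(C(C)=O)cc4)cc32)cc(OC)c1OC`) gives 1540 nM so the two stand level within the scatter. Compound 3 (`COc1cc(-n2cnc3ccc(-c4ccc([N+](=O)[O-])cc4)cc32)cc(OC)c1OC`) carries 4-nitrophenyl in place of 2-methoxyphenyl on an aromatic carbon of the core of compound 1 (4-nitrophenyl in place of 2-methoxyphenyl on an aromatic carbon). Among the compounds with values here, the only measured step bearing on this change, the swap to 4-acetylphenyl, gave a 1.1-fold lower number from compound 1 to compound 2 (0.06 log units; within the scatter) and so no step beyond the scatter is expected in this assay here. The expected step is a 1.3-fold lower number from compound 1 to compound 3 (0.10 log units; within the scatter) by this estimate. Compound 3 is expected at 1400 nM (estimated range 550 nM to 3500 nM).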

Compound 3, half-maximal inhibitory concentration: 740 nM
For compound 3 the middle estimate is 1.9-fold (0.28 log units) above the measured one, within the range that was stated.
By their numbers in this assay, from the lowest: compound 3; then compounds 2 and 1 (each within the scatter of the next).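

In this assay this position on the shared core proves able to respond to the group it carries: 4-nitrophenyl in place of 2-methoxyphenyl gives a real gain (a 2.4-fold lower number from compound 1 to compound 3 (0.37 log units; beyond the scatter)), which the swap to 4-acetylphenyl did not. Nitro in place of acetyl also separates two groups on the same phenyl ring (a 2.1-fold lower number from compound 2 to compound 3 (0.32 log units; beyond the scatter)), though both steps are modest. Nothing measured here accounts for the gain. As far as these compounds go, whether 4-aminophenyl or 4-carboxyphenyl would hold or extend it remains open, as does how a nitro group elsewhere on that ring would compare.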